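Adding a second chloro to compound 3

The compounds below may be only part of what the source reports. "The series", "measured", "known", "first", "only" and "open" are said of these compounds alone.

Compound 1 `O=C1OC[C@H](Cc2ccccc2)[C@H]1Cc1ccccc1O`: 83000 nM
Compound 2 `O=C1OC[C@H](Cc2ccccc2)[C@H]1Cc1ccccc1C(F)(F)F`: 37000 nM
Compound 3 `O=C1OC[C@H](Cc2ccccc2)[C@H]1Cc1ccccc1Cl`: 37000 nM

In a functional assay on HL-60 cells (Homo sapiens) for cytotoxicity, read by WST assay, with a stated time of 48 h (a higher number here means that more compound is needed for the effect, a lower number that less compound is needed), compound 3 gives 37000 nM, level with compound 2, and the two share the lowest of the three numbers. Compound 4 `O=C1OC[C@H](Cc2ccccc2)[C@H]1Cc1ccc(Cl)cc1Cl` differs from compound 3 by one change: chloro in place of hydrogen on an aromatic carbon. A chloro takes the place of a hydrogen on an aromatic carbon, meta to a chloro group and para to a large group. Among the compounds with values here, no measured step adds a group at this place, so the evidence is indirect. Chloro in place of hydroxy gave a 2.2-fold lower number from compound 1 to compound 3 (0.35 log units; beyond the scatter), and trifluoromethyl in place of hydroxy gave a 2.2-fold lower number from compound 1 to compound 2 (0.35 log units; beyond the scatter). Chloro in place of trifluoromethyl gave no change at the digits printed from compound 2 to compound 3 (within the scatter). A small move toward a lower number is therefore expected, probably within the scatter. The estimated step is a 1.5-fold lower number from compound 3 to compound 4 (0.19 log units; within the scatter). Compound 4 is expected at 24000 nM, with an estimated range of 10000 nM to 55000 nM.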

Compound 4, half-maximal effective concentration: 19000 nM
For compound 4 the middle estimate is 1.3-fold (0.10 log units) above the measured one; the measured number falls inside the stated range.
By their numbers in this assay, from the lowest: compounds 4, 2 and 3 (each within the scatter of the next); then compound 1.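

In this assay, within the data shown here, chloro in place of hydrogen on this aromatic carbon gives a 1.9-fold lower number from compound 3 to compound 4 (0.29 log units; within the scatter) and is the only measured step that adds a group at this place. It shows that compound 4, with its second chloro, cannot be told apart from compound 3 in this assay. No measurement shown bears on what lies behind this step. The compounds shown leave open whether an amine, a carboxylic acid or a methoxy group at this place would give a step beyond the scatter.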